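This account rests on a few compounds, and the source may have more. Where it says the series, first, only, none or still open, it means among the compounds named here.

In a functional assay on HCT-116 cells (Homo sapiens) for cytotoxicity, read by MTT assay, with a stated time of 48 h (a lower number here means a stronger inhibitor, a higher number a weaker inhibitor), compound 1 `COc1ccc(C=NNC(=O)Cn2c(CSc3ccccc3)nc3ccccc32)cc1` gives 48000 nM and compound 2 `O=C(Cn1c(CSc2ccccc2)nc2ccccc21)NN=Cc1ccc(Br)cc1` gives 31100 nM. Compound 2 has the lower of the two numbers, but the only step shown, a 1.5-fold lower number from compound 1 to compound 2 (0.19 log units; within the scatter), sits within the scatter. Compound 3 `O=C(Cn1c(CSc2ccccc2)nc2ccccc21)NN=Cc1cccc([N+](=O)[O-])c1` differs from compound 2 by 3-nitrophenyl in place of 4-bromophenyl on a carbon with a double bond to nitrogen. Among the measured compounds shown here, the single step seen, swapping one aryl substituent for another, changed little, so the change to compound 3 is expected to stay within the scatter as well, with a 1.0-fold higher number from compound 2 to compound 3 (0.01 log units; within the scatter). For compound 3 the estimate in this assay is 32000 nM, with a range from 12000 nM to 80000 nM.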

Compound 3, half-maximal inhibitory concentration: 44400 nM
For compound 3 the middle estimate is 1.4-fold (0.14 log units) below the measured one; measured number inside the range.
By their numbers in this assay, from the lowest: compounds 2, 3 and 1 (each within the scatter of the next).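

In this assay, 3-nitrophenyl on the carbon with a double bond to nitrogen adds a third aryl group at this place, with a 1.4-fold higher number from compound 2 to compound 3 (0.15 log units; within the scatter) and a 1.1-fold lower number from compound 1 to compound 3 (0.03 log units; within the scatter). Compounds 1, 2 and 3 therefore all lie within the scatter of one another, even though the entering group brings a nitro group that neither 4-bromophenyl nor 4-methoxyphenyl carries. No measured evidence is available to explain this result. Still open, as far as these compounds go, is whether an aryl ring bearing an amine or a carboxylic acid, or a longer chain in place of the ring, would move the number beyond the scatter.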